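The source may report more compounds than this note shows. Statements on the series, on what has been measured and on what is new or still open speak of the compounds shown alone.

Three ureas on the shared core of compound 1 `COc1ccc(NC(=O)Nc2ccc(Nc3ncnc4c3OCCN4)cc2)cc1` have been run in an assay on isolated protein for inhibition of proto-oncogene tyrosine-protein kinase receptor Ret variant V804L (Homo sapiens), read by 33P incorporation, with stated times of 15 min and 40 min; on this read-out higher numbers stand for weaker inhibition and lower numbers for stronger inhibition. Compound 1 gives 1220 nM. Compound 2 `COc1cccc(NC(=O)Nc2ccc(Nc3ncnc4c3OCCN4)cc2)c1` reaches only a limit in this assay, > 10000 nM (the limit of > 10000 nM in this assay, at which 1 of the 3 values shown sits). Compound 3 `O=C(Nc1ccc(Nc2ncnc3c2OCCN3)cc1)Nc1cc(Cl)cc(Cl)c1` gives 4480 nM, the highest of the two numbers in hand; the step of a 3.7-fold higher number from compound 1 to compound 3 (0.56 log units; beyond the scatter) lies beyond the scatter, as does the step of an at least 2.2-fold lower number from compound 2 to compound 3 (0.34 log units; beyond the scatter) in the other direction. The next member, compound 4 `CC(C)(C)c1cc(NC(=O)Nc2ccc(Nc3ncnc4c3OCCN4)cc2)no1`, carries 5-(tert-butyl)-1,2-oxazol-3-yl in place of 3,5-dichlorophenyl on an amide-type nitrogen. The measured steps of an at least 8.1-fold higher number from compound 1 to compound 2 (0.91 log units; beyond the scatter) and a 3.7-fold higher number from compound 1 to compound 3 (0.56 log units; beyond the scatter) both swap one aryl group on that nitrogen for another, and they bear on the present change only in showing that such swaps move this assay by modest amounts, in either direction. A step of similar size is therefore expected in this assay, with no firm direction. The estimate for compound 4 is 3000 nM, in the range 800 nM to 12000 nM. This expected value corresponds to the step of a 1.5-fold lower number from compound 3 to compound 4 (0.17 log units; within the scatter).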

Compound 4, half-maximal inhibitory concentration: 58 nM
The estimate for compound 4 lay 52-fold (1.71 log units) above the measured number; measured number outside the range, below it.
By their numbers in this assay, from the lowest: compound 4; then compound 1; then compound 3. At a limit, above all of these: compound 2.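

In this assay, placing 5-(tert-butyl)-1,2-oxazol-3-yl on the amide-type nitrogen gives large steps, a 77-fold lower number from compound 3 to compound 4 (1.89 log units; beyond the scatter) and a 21-fold lower number from compound 1 to compound 4 (1.32 log units; beyond the scatter), whereas swaps among the substituted phenyl groups stayed modest. This position therefore responds far more strongly than those swaps suggested, and compound 4 is the strongest inhibitor of the four, with its steps to all the others beyond the scatter. The third step, an at least 170-fold lower number from compound 2 to compound 4 (2.23 log units; beyond the scatter), starts from a limit rather than a number, so it gives only a bound on the size of the change: the limit of > 10000 nM in this assay, at which 1 of the 4 values shown sits.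

The ring and the tert-butyl group change together here, so the compounds shown cannot say which of them carries the gain. A phenyl ring bearing tert-butyl, or the same 1,2-oxazole ring bearing methyl, would separate the two.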